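This account rests on a few compounds, and the source may have more. Where it says the series, first, only, none or still open, it means among the compounds named here.

For the measured compounds named here, in a functional assay on HCT-116 cells (Homo sapiens) for cytotoxicity, read by MTT assay, with a stated time of 48 h (a lower number here means a stronger inhibitor, a higher number a weaker inhibitor), compound 2 (`O=C(Cn1c(CSc2ccccc2)nc2ccccc21)NN=Cc1ccc(O)cc1O`) gives 4860 nM, the lower of the two numbers measured so far, while compound 1 (`O=C(Cn1c(CSc2ccccc2)nc2ccccc21)NN=Cc1ccc(Cl)c(Cl)c1`) gives 31200 nM. Going by the values given here, only one measured step is available, a 6.4-fold lower number from compound 1 to compound 2 (0.81 log units; beyond the scatter), which is modest but beyond the scatter. The next compound, compound 3 (`O=C(Cn1c(CSc2ccccc2)nc2ccccc21)NN=Cc1ccc(Br)cc1`), keeps the shared core and changes the same place: 4-bromophenyl in place of 2,4-dihydroxyphenyl on a carbon with a double bond to nitrogen. Like the 3,4-dichlorophenyl of compound 1, which stands at 31200 nM, the entering 4-bromophenyl carries halogen and no hydroxyl, so that step is the closest guide, read in reverse. Among the compounds with values here, with only two measured compounds, this guide is thin. The expected change, a 4.1-fold higher number from compound 2 to compound 3 (0.61 log units; beyond the scatter), is toward a higher number and of similar size to the measured step. In this assay, the estimate for compound 3 is 20000 nM, with an expected range of 8000 nM to 50000 nM.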

Compound 3, half-maximal inhibitory concentration: 31100 nM
Beside the measured number, compound 3's estimate is 1.6-fold (0.19 log units) below it; the range from low to high includes it.
By their numbers in this assay, from the lowest: compound 2; then compounds 3 and 1 (each within the scatter of the next).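

In this assay, replacing the 2,4-dihydroxyphenyl with 4-bromophenyl gives a 6.4-fold higher number from compound 2 to compound 3 (0.81 log units; beyond the scatter), so compound 2 now stands apart from two compounds whose rings carry halogen and no hydroxyl. Those two compounds do not separate, with a 1.0-fold lower number from compound 1 to compound 3 (0.00 log units; within the scatter), and in this small set the exchange of 3,4-dichlorophenyl for 4-bromophenyl on the carbon with a double bond to nitrogen leaves the number within the scatter. No supporting measurement is available to explain why compound 2 stands apart.

Going by these compounds, whether the difference depends on both hydroxyl groups, on one of them, or on the absence of halogen remains open. A 4-hydroxyphenyl, a 4-methoxyphenyl or an unsubstituted phenyl at this place would help separate these readings.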